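The compounds below may be only part of what the source reports. "The series", "measured", "known", "first", "only" and "open" are said of these compounds alone.

Values measured in a functional assay on MDA-MB-231 cells (Homo sapiens) for cytotoxicity, read by MTT assay, with a stated time of 48 h; on this read-out lower numbers stand for stronger inhibition and higher numbers for weaker inhibition:
- compound 1 `O=C(NCCCCC(c1ccc(F)cc1)c1ccc(F)cc1)Nc1ccc(I)cc1`: 11800 nM
- compound 2 `Cc1cccc(NC(=O)NCCCCC(c2ccc(F)cc2)c2ccc(F)cc2)c1`: > 20000 nM (a limit of the assay, not a number)
- compound 3 `O=C(NCCCCC(c1ccc(F)cc1)c1ccc(F)cc1)Nc1ccc(Cl)c(C(F)(F)F)c1`: 3150 nM

Compound 3 has the lowest value of the set, so it is the strongest of these three in this assay. For the measured compounds named here, the only other true number belongs to compound 1, and the remaining entry is the limit of > 20000 nM in this assay, at which 1 of the 3 values shown sits.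

The next compound, compound 4 `CC(=O)Nc1cc(NC(=O)NCCCCC(c2ccc(F)cc2)c2ccc(F)cc2)ccc1Cl`, keeps the shared core and the chloro group. Acetamido takes the place of trifluoromethyl on an aromatic carbon, ortho to that chloro group: acetamido in place of trifluoromethyl on an aromatic carbon.

Going by the values given here, no measured step makes this exact swap, so the nearest guides are the changes to the same aromatic group. These are a 3.7-fold lower number from compound 1 to compound 3 (0.57 log units; beyond the scatter) and an at least 6.3-fold lower number from compound 2 to compound 3 (0.80 log units; beyond the scatter), while an at least 1.6-fold higher number from compound 1 to compound 2 (0.22 log units; that floor lies within the scatter) adds little. They show that this group can shift the value, and that both other versions, in compound 1 and compound 2, sit higher than compound 3. Losing the group found in compound 3 therefore points to a modest rise rather than a fall, though the size is uncertain.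

The expected step is a 2.5-fold higher number from compound 3 to compound 4 (0.40 log units; beyond the scatter). For compound 4 the estimated value is 8000 nM, with an expected range of 3000 nM to 20000 nM.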

Compound 4, half-maximal inhibitory concentration: 9120 nM
Estimate against measurement, compound 4: 1.1-fold (0.06 log units) below, within the range that was stated.
By their numbers in this assay, from the lowest: compound 3; then compounds 4 and 1 (each within the scatter of the next). At a limit, above all of these: compound 2.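

Replacing trifluoromethyl with acetamido, which brings a hydrogen-bond donor and a hydrogen-bond acceptor where the old group has none, gives a 2.9-fold higher number from compound 3 to compound 4 (0.46 log units; beyond the scatter) in this assay, so with the chloro group held fixed, the group at this position, ortho to that chloro group, changes the value on its own. The 3-acetamido-4-chlorophenyl group and the 4-iodophenyl group give values that cannot be told apart, with a 1.3-fold lower number from compound 1 to compound 4 (0.11 log units; within the scatter). Against the 3-methylphenyl group the new group gives an at least 2.1-fold lower number from compound 2 to compound 4 (0.34 log units; beyond the scatter), a step that starts from a limit of the assay rather than a number, so only its floor is known: the limit of > 20000 nM in this assay, at which 1 of the 4 values shown sits.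

The compounds shown leave open how other groups at this same position, such as an amine or a carboxylic acid, would compare with trifluoromethyl and acetamido. For the compounds shown here, also open is what the chloro group itself contributes, as both compounds with a group at this position ortho to chloro carry it, and no pair here isolates it.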